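The source may report more compounds than this note shows. Statements on the series, on what has been measured and on what is new or still open speak of the compounds shown alone.

Compound 1 `Cn1c(-c2ccc(-c3cncnc3)cc2)nnc1C1(c2ccc(Cl)cc2)CCC1` stands lowest of the three numbers available: in a functional assay on the whole organism (strain ICR) for inhibition, with Mus musculus as the target, read by scintillation counting, with a stated time of 16 h, at a dose of 10 mg/kg by the oral route (a lower number here means less inhibition, a higher number more inhibition at the dose given (going by the name of the read-out)), compound 1 gives -4%. Compound 2 `CC(=O)Nc1ccc(-c2nnc(C3(c4ccc(Cl)cc4)CCC3)n2C)c(Cl)c1` gives 27% and compound 3 `Cn1c(-c2ccc(-c3cccnc3)cc2Cl)nnc1C1(c2ccc(Cl)cc2)CCC1` gives 26%, each a number beyond the scatter above compound 1.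

Compound 4 `Cn1c(-c2ccc(C(=O)NC(C)(C)C)cc2)nnc1C1(c2ccc(Cl)cc2)CCC1` has not yet been measured. Its change from compound 1 is (tert-butyl)carbamoyl in place of pyrimidin-5-yl on an aromatic carbon. Going by the values given here, the one measured step that bears on an exchange of this kind is a number 1 percentage points lower from compound 2 to compound 3 (within the scatter), where an amide group gave way to an aromatic heterocycle and the number stayed within the scatter. Among the compounds with values here, the present change runs the other way, from an aromatic heterocycle to an amide, so by that precedent no large step is expected, although the low starting point of compound 1 leaves room for a rise that no measured step proves. The step from compound 1 to compound 4 is therefore expected to be a number 14 percentage points higher from compound 1 to compound 4 (beyond the scatter), a modest rise of uncertain size. Compound 4 is estimated at 10%, with a range from -12% to 34%.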

Compound 4, a percentage reported as inhibition, in the whole organism at one dose (the size of the read-out at that dose, not a potency): 5%
Compound 4: the middle estimate sits 5 percentage points above what was measured; the range from low to high includes it.
By their numbers in this assay, from the lowest: compounds 1 and 4 (each within the scatter of the next); then compounds 3 and 2 (each within the scatter of the next).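

In this assay the exchange gives a number 9 percentage points higher from compound 1 to compound 4 (within the scatter): on an aromatic carbon para to a large group, the open-chain (tert-butyl)carbamoyl, with its hydrogen-bond donor, takes the place of the pyrimidin-5-yl ring without a change that can be told from scatter. Going by these compounds alone, the earlier exchange between an amide group and an aromatic heterocycle was seen only in compounds carrying a chloro group on that same ring, so this is the first such reading without it. Nothing available bears on the reason for this result.

As far as these compounds go, whether another group at this place, such as a carboxylic acid, an amine or the smaller methylcarbamoyl, would move the number beyond the scatter stays open. No pair shown differs by the chloro group alone, so its part in the higher numbers of compound 2 and compound 3 is open too.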